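The source may report more compounds than this note shows. Statements on the series, on what has been measured and on what is new or still open speak of the compounds shown alone.

Measured so far:
compound 1 `COC(=O)c1c[nH]c2cc(N3CCN(c4ccccc4)CC3)ccc2c1=O`: > 20000 nM
compound 2 `COC(=O)c1c[nH]c2cc(CN3CCN(c4ccc(C(F)(F)F)cc4)CC3)c(OC)cc2c1=O`: > 20000 nM

Both compounds were tested in an ADME assay on J774 cells (Mus musculus) for cytotoxicity, with a stated time of 72 h; on this read-out higher numbers stand for an effect only at larger amounts of compound and lower numbers for an effect already at smaller amounts. For compound 1, the entry > 20000 nM is a limit and not a number. The entry for compound 2, > 20000 nM, is likewise a limit. Among the compounds with values here, compound 1 therefore stands with the only other compound tested, and the record for this assay reads: the limit of > 20000 nM in this assay, at which 2 of the 2 values shown sit. No exact value marks its position.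

Compound 3 `COC(=O)c1c[nH]c2cc(N3CCN(c4ccccc4)CC3)c(C)cc2c1=O` has the core of compound 1 with one change: methyl in place of hydrogen on an aromatic carbon, ortho to a large group. Within the data shown here, no measured pair shows what a single change does in this assay, so any expectation here is tentative. The expectation is no shift beyond the usual scatter in either direction, and compound 3 may well return only a limit again. The estimated change is a step that the limit leaves unreadable from compound 1 to compound 3. For compound 3 the expected value is 24000 nM, with an estimated range from 10000 nM to 50000 nM.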

Compound 3, half-maximal effective concentration: 17000 nM
For compound 3 the middle estimate is 1.4-fold (0.15 log units) above the measured one; the range from low to high includes it.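

Within the data shown here, compound 3 gives the first exact number in this assay, 17000 nM, so methyl in place of hydrogen on this aromatic carbon, ortho to a large group, brings the series its first value that is not a limit. Among these compounds, the change also supplies the first single-change step on this read-out, an at least 1.1-fold lower number from compound 1 to compound 3 (0.07 log units; that floor lies within the scatter), and that step is only a floor, so its true size cannot be read and it does not establish a real shift. Compound 3 therefore stands alone with an exact number, while the rest of the record remains at a limit: the limit of > 20000 nM in this assay, at which 2 of the 3 values shown sit.

The compounds shown leave open whether a larger or different group on this same carbon, such as an ethyl chain, a chlorine atom, an amine or a carboxylic acid, would move the number clearly beyond the scatter, or whether methyl would do so on another carbon of the core. Compound 2 differs from compound 1 and compound 3 in more than one place, so it cannot settle either question.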